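Working notes: from compound 2 to compound 4

A few compounds are considered here, and "the series" means these few. Any claim that something is new, unique, unknown or untested is made for them only; others in the source may bear on it.

Measured so far:
Compound 1 `c1ccc(C(c2c[nH]c3ccccc23)c2c[nH]c3ccccc23)cc1` gives 21800 nM
Compound 2 `COc1ccc(C(c2c[nH]c3ccc(Br)cc23)c2c[nH]c3ccc(Br)cc23)cc1` gives 5500 nM
Compound 3 `COc1ccc(C(c2c[nH]c3ccc(Br)cc23)c2c[nH]c3ccc(Br)cc23)c(OC)c1` gives 63200 nM

In a functional assay on HeLa cells (Homo sapiens) for inhibition, read by MTT assay, with a stated time of 48 h (on this read-out higher numbers stand for weaker inhibition and lower numbers for stronger inhibition), compound 2 has the lowest number of the three, and compound 1 and compound 3 both sit beyond the scatter from it. The change to compound 4 `COc1ccc(OC)c(C(c2c[nH]c3ccc(Br)cc23)c2c[nH]c3ccc(Br)cc23)c1` is 2,5-dimethoxyphenyl in place of 4-methoxyphenyl on a saturated chain carbon bound to two aromatic carbons and leaves the shared core untouched. Among the compounds with values here, one measured step bears on it: an 11-fold higher number from compound 2 to compound 3 (1.06 log units; beyond the scatter) is large, and it also adds a methoxy to the aryl group on that chain carbon. Compound 3 does not carry the 2,5-dimethoxyphenyl group of compound 4, so that step is only a partial guide. Resting on an 11-fold higher number from compound 2 to compound 3 (1.06 log units; beyond the scatter) as the sole precedent, a higher number is expected in this assay with a rise of smaller size than that one. The estimated change is a 3.6-fold higher number from compound 2 to compound 4 (0.56 log units; beyond the scatter) and it would mean weaker inhibition. Compound 4 is expected near 20000 nM with an estimated range from 6000 nM to 70000 nM as the working guess.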

Compound 4, half-maximal inhibitory concentration: 5100 nM
For compound 4 the middle estimate is 3.9-fold (0.59 log units) above the measured one; the measured number lies below the stated range.
By their numbers in this assay, from the lowest: compounds 4 and 2 (each within the scatter of the next); then compound 1; then compound 3.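

Within this assay the change to 2,5-dimethoxyphenyl on the saturated chain carbon gives a 1.1-fold lower number from compound 2 to compound 4 (0.03 log units; within the scatter) and shows that a second methoxy on this aryl group does not by itself raise the number. The change from 2,4-dimethoxyphenyl to 2,5-dimethoxyphenyl gives a 12-fold lower number from compound 3 to compound 4 (1.09 log units; beyond the scatter) and shows that this position distinguishes between the two dimethoxyphenyl groups, with compound 3 the one that stands apart from compound 2 and compound 4. No data shown account for that difference between the two groups.

From the compounds shown here alone, whether a hydroxy group, an amine or a carboxylic acid on this aryl group would be tolerated at the saturated chain carbon remains open. Also open, going by these compounds, is what the bromine on the shared core contributes on its own.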